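Sulfonyl substituent change in the vinyl sulfone series

The compounds below may be only part of what the source reports. "The series", "measured", "known", "first", "only" and "open" are said of these compounds alone.

For the measured compounds named here, compound 3 `Cc1ccc(CS(=O)(=O)/C(=C/c2ccc(C)s2)C(=O)c2ccc(Cl)cc2)cc1` gives 25000 nM in a functional assay on DU-145 cells (Homo sapiens) for inhibition, read by trypan blue exclusion, with a stated time of 96 h (a lower number here means a stronger inhibitor of growth, a higher number a weaker inhibitor of growth), and stands highest of the three numbers measured so far. Compound 1 `Cc1ccc(/C=C(\C(=O)c2ccc(Cl)cc2)S(=O)(=O)Cc2ccc(Cl)cc2)s1` gives 1000 nM in this assay, and compound 2 `Cc1ccc(CS(=O)(=O)/C(=C/c2cc(C)ccc2C)C(=O)c2ccc(Cl)cc2)cc1` gives 1000 nM. Both measured steps end at compound 3 and are large: a 25-fold higher number from compound 1 to compound 3 (1.40 log units; beyond the scatter) and a 25-fold higher number from compound 2 to compound 3 (1.40 log units; beyond the scatter). Compound 4 `COc1ccc(S(=O)(=O)/C(=C/c2ccc(C)s2)C(=O)c2ccc(Cl)cc2)cc1` differs from compound 3 by 4-methoxyphenyl in place of 4-methylbenzyl on a sulfonyl sulfur. Going by the values given here, neither measured step touches the sulfonyl sulfur: one alters a ring substituent, the other the group on the double-bonded chain carbon, so no measured step bears on this change and there is no basis for a direction. The step in this assay is therefore expected to fall within the scatter, no change at the digits printed from compound 3 to compound 4 (within the scatter). Compound 4 is estimated at 25000 nM in this assay, with a wide range from 6000 nM to 100000 nM that reflects the absence of any comparable measured step.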

Compound 4, concentration for 50% growth inhibition: 25000 nM
For compound 4 middle estimate and measured number coincide at the digits printed, and the stated range covers the measured number.
By their numbers in this assay, from the lowest: compounds 1 and 2 (each within the scatter of the next); then compounds 3 and 4 (each within the scatter of the next).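

Changing the group on the sulfonyl sulfur does not by itself move the number in this assay: no change at the digits printed from compound 3 to compound 4 (within the scatter), so 4-methoxyphenyl and 4-methylbenzyl cannot be told apart here when 5-methylthiophen-2-yl sits on the shared core. The other step at this sulfur, a 25-fold higher number from compound 1 to compound 4 (1.40 log units; beyond the scatter), is large and matches a 25-fold higher number from compound 1 to compound 3 (1.40 log units; beyond the scatter), which leaves 4-chlorobenzyl as the only one of the three sulfonyl groups giving the lower number with this core. Nothing on hand explains either the flat step or the large one.

Open, from the compounds shown here alone, is whether a 4-methoxybenzyl or 4-chlorophenyl group on the sulfur would separate the effect of the ring substituent from that of the benzyl carbon. Also open, going by these compounds, is whether the flat step holds with 2,5-dimethylphenyl on the double-bonded chain carbon, or with an amine or a carboxylic acid on the sulfonyl aryl ring.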